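Bromophenyl Ketone Estimated From Methoxy Analogues

This account rests on a few compounds, and the source may have more. Where it says the series, first, only, none or still open, it means among the compounds named here.

Compound 3 `COc1ccc(Nc2nc(N)c(C(=O)c3cccc(OC)c3)s2)cc1` holds the lowest number among the three measured in a functional assay on MOLT-4 cells (Homo sapiens) for antiproliferative activity, read by cell counting, with a stated time of 2 days (a higher number here means a weaker inhibitor, a lower number a stronger inhibitor), where compound 3 gives 4 nM, with compound 2 `COc1ccc(Nc2nc(N)c(C(=O)c3ccc(OC)c(OC)c3)s2)cc1` at 37 nM and compound 1 `COc1cccc(C(=O)c2sc(Nc3ccccc3)nc2N)c1` at 1300 nM. Compound 4 `COc1ccc(Nc2nc(N)c(C(=O)c3ccc(Br)cc3)s2)cc1` differs from compound 3 in one place: 4-bromophenyl in place of 3-methoxyphenyl on a carbonyl carbon. Among the measured compounds shown here, two measured steps bear on this. The large one, a 330-fold lower number from compound 1 to compound 3 (2.51 log units; beyond the scatter), concerns a methoxy elsewhere on the shared core. The closer one, a 9.3-fold lower number from compound 2 to compound 3 (0.97 log units; beyond the scatter), shows a modest effect of changing a methoxy on the same ring that is now replaced. Because of a 9.3-fold lower number from compound 2 to compound 3 (0.97 log units; beyond the scatter) the expected step of a 5.0-fold higher number from compound 3 to compound 4 (0.70 log units; beyond the scatter) is modest and toward a higher number. Compound 4 is therefore estimated at 20 nM, within 4 nM to 100 nM.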

Compound 4, half-maximal inhibitory concentration: 16 nM
For compound 4 the middle estimate is 1.3-fold (0.10 log units) above the measured one, within the range that was stated.
By their numbers in this assay, from the lowest: compound 3; then compound 4; then compound 2; then compound 1.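

In this assay, 4-bromophenyl in place of 3-methoxyphenyl on a carbonyl carbon gives a 4.0-fold higher number from compound 3 to compound 4 (0.60 log units; beyond the scatter), a modest step beyond the scatter. The earlier steps shown here changed only methoxy groups, whereas this one shows that the ring on the carbonyl carbon can carry bromine and no methoxy, with compound 4 still at 16 nM in the nanomolar range. No measured evidence accounts for this step. The compounds shown leave open whether the step follows from the bromine, its place on the ring or the lost methoxy, and how an amine or a carboxylic acid there would read.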